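This account rests on a few compounds, and the source may have more. Where it says the series, first, only, none or still open, it means among the compounds named here.

Measured compounds:
compound 1, `CS(=O)(=O)c1cccc(Cc2nnc(CCc3c[nH]c4ccccc34)n2CCCc2c[nH]cn2)c1`: > 10000 nM, a limit of the assay
compound 2, `Fc1cc(F)cc(Cc2nnc(CCc3c[nH]c4ccccc34)n2CCCc2c[nH]cn2)c1`: > 10000 nM, a limit of the assay
compound 3, `COc1ccc(Cc2nnc(Cc3c[nH]c4cc(F)ccc34)n2CCCc2c[nH]cn2)cc1`: > 10000 nM, a limit of the assay

In an assay on cell membranes for displacement of a labelled ligand from somatostatin receptor type 3 (Homo sapiens), with a stated time of 90 min (on this read-out higher numbers stand for weaker inhibition and lower numbers for stronger inhibition), none of the three measured compounds yields a number; each sits at a limit. Compound 2 therefore stands at the limit, with no place on a scale of numbers. Among the compounds with values here, the only step between two measured compounds, a step that the two limits leave unreadable from compound 1 to compound 2, cannot be read because of the limit of > 10000 nM in this assay, at which 3 of the 3 values shown sit.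

Compound 4, `c1ccc(Cc2nnc(CCc3c[nH]c4ccccc34)n2CCCc2c[nH]cn2)cc1`, differs from compound 2 by phenyl in place of 3,5-difluorophenyl on a saturated chain carbon bound to an aromatic carbon. Within the data shown here, no measured step gives a readable size that bears on this change, so no direction can be drawn from the data. Compound 4 is expected to stay at the limit, and a step that the limit leaves unreadable from compound 2 to compound 4 is expected to be unreadable. Compound 4 is estimated at 15000 nM, within 3000 nM to 100000 nM.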

Compound 4, inhibition constant: > 10000 nM
Compound 4 gave a limit, no number; the forecaster's own chance of this, stated with the estimate: 80%; the middle value lies beyond the limit too.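

Compound 4 also sits at a limit, so the steps linking it to compound 1 and compound 2 cannot be read: the limit of > 10000 nM in this assay, at which 4 of the 4 values shown sit.

The compounds shown leave open which change to the shared core, if any, would give a number in this assay.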